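The source may report more compounds than this note shows. Statements on the series, on what has been measured and on what is new or still open speak of the compounds shown alone.

Working notes on the series. For the measured compounds named here, in an ADME assay on CCRF-CEM cells (Homo sapiens) for antiproliferative activity, with a stated time of 48 h (a lower number here means a stronger inhibitor, a higher number a weaker inhibitor), compound 2 (`Nc1ccc(/C=C/C(=O)c2ccc(Br)cc2)cc1`) gives 14000 nM, the higher of the two numbers so far. Compound 1 (`C=C(Br)C(=O)Nc1ccc(/C=C/C(=O)c2ccc(I)cc2)cc1`) gives 4000 nM, a lower number by more than the scatter. Compound 1 differs from compound 2 in more than one place, so this gap does not isolate any single change.

Compound 3 (`Nc1ccc(/C=C/C(=O)c2ccc(I)cc2)cc1`) is the next structure to read against compound 2. The change is iodo in place of bromo on an aromatic carbon. Going by the values given here, no measured pair covers this exchange, so the expectation is only a small step, with no change beyond the scatter in this assay and at most a slight drift to a lower number. The expected step of a 1.3-fold lower number from compound 2 to compound 3 (0.10 log units; within the scatter) is an estimate. For compound 3 the estimated value is 11000 nM, with an expected range of 5000 nM to 22000 nM.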

Compound 3, half-maximal inhibitory concentration: 16000 nM
For compound 3 the middle estimate is 1.5-fold (0.16 log units) below the measured one, and the stated range covers the measured number.
By their numbers in this assay, from the lowest: compound 1; then compounds 2 and 3 (each within the scatter of the next).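

In this assay, iodo in place of bromo on an aromatic carbon, para to a large group, gives a 1.1-fold higher number from compound 2 to compound 3 (0.06 log units; within the scatter), so this exchange does not separate the two compounds at this position. With iodo held constant, the earlier gap now has a single change behind it: hydrogen in place of (1-bromoethenyl)carbonyl on the nitrogen gives a 4.0-fold higher number from compound 1 to compound 3 (0.60 log units; beyond the scatter). No measurement shown bears on the reason for either step.

As far as these compounds go, whether a chloro or fluoro at the same position would also stay within the scatter remains open. Also open, from the compounds shown here alone, is whether the step at the nitrogen needs the bromoethenyl part, which a plain acetyl group on that nitrogen would test.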